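A few compounds are considered here, and "the series" means these few. Any claim that something is new, unique, unknown or untested is made for them only; others in the source may bear on it.

In a functional assay on LNCaP cells (Homo sapiens) for cytotoxicity, read by MTT assay (a higher number here means a weaker inhibitor, a lower number a stronger inhibitor), three compounds that share one core and differ only in the group on a saturated chain carbon bound to a sulfur have been measured. Compound 1 `COc1ccc2cc([C@H](C)c3nnc(SCc4ccc(F)cc4)n3-c3ccc(F)cc3)ccc2c1` gives 104000 nM, compound 2 `COc1ccc2cc([C@H](C)c3nnc(SCc4c(Cl)cccc4Cl)n3-c3ccc(F)cc3)ccc2c1` gives 12300 nM, and compound 3 `COc1ccc2cc([C@H](C)c3nnc(SCc4c(C)cc(C)cc4C)n3-c3ccc(F)cc3)ccc2c1` gives 2210 nM, the lowest number of the three. Compound 4 `COc1cccc(CSc2nnc([C@@H](C)c3ccc4cc(OC)ccc4c3)n2-c2ccc(F)cc2)c1` is not yet measured, and it carries 3-methoxyphenyl in place of 2,4,6-trimethylphenyl on a saturated chain carbon bound to a sulfur.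

Going by the values given here, three measured steps bear on this change, all at the same place and all beyond the scatter. The large one is a 47-fold lower number from compound 1 to compound 3 (1.67 log units; beyond the scatter), and the two modest ones are an 8.5-fold lower number from compound 1 to compound 2 (0.93 log units; beyond the scatter) and a 5.6-fold lower number from compound 2 to compound 3 (0.75 log units; beyond the scatter). None of them involves 3-methoxyphenyl itself. Its nearest measured counterpart is the 4-fluorophenyl of compound 1, at 104000 nM, so a rise of modest to large size is expected in this assay. The expected step is a 14-fold higher number from compound 3 to compound 4 (1.13 log units; beyond the scatter). Compound 4 is estimated at 30000 nM, with an expected range of 8000 nM to 110000 nM.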

Compound 4, half-maximal inhibitory concentration: 14500 nM
Estimate against measurement, compound 4: 2.1-fold (0.32 log units) above, within the range that was stated.
By their numbers in this assay, from the lowest: compound 3; then compounds 2 and 4 (each within the scatter of the next); then compound 1.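

In this assay the change to 3-methoxyphenyl gives a 6.6-fold higher number from compound 3 to compound 4 (0.82 log units; beyond the scatter) and so leaves compound 3 with the lowest number of the four, its steps to all the others being beyond the scatter. The same group, the only one here with an oxygen and a hydrogen-bond acceptor, does not stay level with 4-fluorophenyl, as a 7.2-fold lower number from compound 1 to compound 4 (0.86 log units; beyond the scatter) shows, and it cannot be told apart from 2,6-dichlorophenyl, as a 1.2-fold higher number from compound 2 to compound 4 (0.07 log units; within the scatter) shows. Rings bearing one substituent therefore do not share a single level at this position, since compound 1 and compound 4 differ beyond the scatter.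

As far as these compounds go, whether 4-methoxyphenyl, or a ring carrying an amine or a carboxylic acid, would fall nearer compound 3 or compound 1 remains open. Nothing given here explains why these groups differ.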